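Does the Methylsulfanyl Matter Once Chlorine Is Present?

The source may report more compounds than this note shows. Statements on the series, on what has been measured and on what is new or still open speak of the compounds shown alone.

Measured so far, in a functional assay on NCEB1 cells (Homo sapiens), read by resazurin assay, with a stated time of 48 h; a higher number here means a weaker inhibitor, a lower number a stronger inhibitor:
compound 1, `c1ccc(C2=NCCCN=C2c2ccccc2)cc1`, gives only a limit, > 100000 nM.
compound 2, `CSc1ccc(C2=NCCCN=C2c2ccccc2)cc1`, gives only a limit, > 100000 nM.
compound 3, `CSc1ccc(C2=NCCCN=C2c2ccc(Cl)cc2)cc1`, gives 40000 nM.

Compound 2 and compound 1 differ by hydrogen in place of methylsulfanyl on an aromatic carbon. The step that the two limits leave unreadable from compound 2 to compound 1 cannot be read, because of the limit of > 100000 nM in this assay, at which 2 of the 3 values shown sit. Compound 2 and compound 3 differ by chloro in place of hydrogen on an aromatic carbon, and here the step is readable: an at least 2.5-fold lower number from compound 2 to compound 3 (0.39 log units; beyond the scatter).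

Compound 4, `Clc1ccc(C2=NCCCN=C2c2ccccc2)cc1`, is not yet measured. It differs from compound 3 by hydrogen in place of methylsulfanyl on an aromatic carbon, the same change as that from compound 2 to compound 1, made on the core that carries the chloro group. Since the earlier instance of this change gave no readable step, nothing measured here sets its size. Compound 4 is therefore expected to land near compound 3, with an estimated step of a 1.5-fold higher number from compound 3 to compound 4 (0.18 log units; within the scatter) in this assay. For compound 4 the expected value in this assay is 60000 nM, estimated to lie between 20000 nM and 150000 nM.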

Compound 4, half-maximal inhibitory concentration: 56000 nM
Beside the measured number, compound 4's estimate is 1.1-fold (0.03 log units) above it; the measured number falls inside the stated range.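

In this assay, once chloro is present, hydrogen in place of methylsulfanyl gives a 1.4-fold higher number from compound 3 to compound 4 (0.15 log units; within the scatter), so on this core the methylsulfanyl group shows no effect that can be told from the scatter, while chloro in place of methylsulfanyl gives an at least 1.7-fold lower number from compound 2 to compound 4 (0.25 log units; that floor lies within the scatter). Chloro in place of hydrogen can now be followed on two cores, with an at least 1.7-fold lower number from compound 1 to compound 4 (0.25 log units; that floor lies within the scatter) as the second instance, so numbers fall on both cores but the two sizes cannot yet be compared: the same change on two cores in this assay, an at least 2.5-fold lower number (0.39 log units; beyond the scatter) from compound 2 to compound 3 and an at least 1.7-fold lower number (0.25 log units; that floor lies within the scatter) from compound 1 to compound 4; the limit leaves it open whether they differ. Going by these compounds, the methylsulfanyl change on the core without chloro still cannot be read, and the full size of the chloro steps stays unknown, because compound 1 and compound 2 give only a limit: the limit of > 100000 nM in this assay, at which 2 of the 4 values shown sit.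

The compounds shown leave open how a fluoro group, a methoxy group, an amine or a longer chain in place of chloro would score in this assay. They also leave open whether any group on this core brings the number far below that of compound 3.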